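Propyl in Place of Methoxy: What to Expect for Compound 4

The compounds below may be only part of what the source reports. "The series", "measured", "known", "first", "only" and "open" are said of these compounds alone.

Compound 1 `C[C@@H]1CN(c2sc(Br)nc2-c2nc3ccccc3[nH]2)CCN1C(=O)Cn1cnc2cccnc21` in a functional assay on U2OS cells for antagonist activity at C-X-C chemokine receptor type 3 (Homo sapiens), read by beta-arrestin recruitment (a higher number here means a weaker inhibitor, a lower number a stronger inhibitor), gives 126 nM.
Compound 2 `C[C@@H]1CN(c2sc(CO)nc2-c2nc3ccccc3[nH]2)CCN1C(=O)Cn1cnc2cccnc21` in this assay reaches only the assay limit > 10000 nM.
Compound 3 `COc1ncc(-c2nc(C(F)(F)F)sc2N2CCN(C(=O)Cn3cnc4cccnc43)[C@H](C)C2)cn1` in this assay gives 177 nM.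

Compound 3 and compound 1 sit within the scatter of each other, so no order between them can be read. Compound 4 `CCCc1ncc(-c2nc(C(F)(F)F)sc2N2CCN(C(=O)Cn3cnc4cccnc43)[C@H](C)C2)cn1` differs from compound 3 by propyl in place of methoxy on an aromatic carbon. Going by the values given here, the only measured step, an at least 79-fold higher number from compound 1 to compound 2 (1.89 log units; beyond the scatter), concerns a different group on a different ring, where a limit of > 10000 nM in this assay, at which 1 of the 3 values shown sits, bounds it, and therefore does not bear directly on this exchange. Among the compounds with values here, no measured step speaks to propyl against methoxy at this position. The step from compound 3 to compound 4 is expected to be small, a 1.1-fold higher number from compound 3 to compound 4 (0.05 log units; within the scatter), with no direction favoured. Compound 4 is therefore estimated at 200 nM, between 70 nM and 700 nM.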

Compound 4, half-maximal inhibitory concentration: 33 nM
For compound 4 the middle estimate is 6.1-fold (0.78 log units) above the measured one; measured number below the stated range.
By their numbers in this assay, from the lowest: compound 4; then compounds 1 and 3 (each within the scatter of the next). At a limit, above all of these: compound 2.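

The exchange of 2-methoxypyrimidin-5-yl for 2-propylpyrimidin-5-yl gives a 5.4-fold lower number from compound 3 to compound 4 (0.73 log units; beyond the scatter) in this assay, so this carbon between two ring nitrogen atoms is sensitive to the group it carries. Inhibition does not depend on the methoxy oxygen, and a chain of carbon alone is accepted here. Nothing measured among these compounds accounts for this step. On these data alone, whether chain length or loss of the oxygen drives the change remains open. An ethyl group, a butyl group or an amine at this carbon would help separate the two.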